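From Compound 2 to Compound 3: Losing the Substituent

A few compounds are considered here, and "the series" means these few. Any claim that something is new, unique, unknown or untested is made for them only; others in the source may bear on it.

In a functional assay on DU-145 cells (Homo sapiens) for inhibition (a lower number here means a stronger inhibitor, a higher number a weaker inhibitor), compound 1 (`CCOc1ccc(Br)cc1-c1cc(Nc2ccc(B(O)O)cc2)nc(N)n1`) gives 500 nM. Compound 2 (`CCOc1ccc(Br)cc1-c1cc(Nc2ccc(/C(C)=N\O)cc2)nc(N)n1`) gives < 50 nM, which is a limit of the assay and not a number. Going by the values given here, the only measured step, an at least 10-fold lower number from compound 1 to compound 2 (1.00 log units; beyond the scatter), is beyond the scatter, and its size is itself bounded by that limit, as the limit of < 50 nM in this assay, at which 1 of the 2 values shown sits, records.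

Compound 3 (`CCOc1ccc(Br)cc1-c1cc(Nc2ccccc2)nc(N)n1`) differs from compound 2 by a hydrogen atom in place of a group of 4 heavy atoms (2 carbon, 1 nitrogen, 1 oxygen; no ring), on an aromatic carbon, on a six-membered aromatic ring of carbon only, para to a large group. Among the compounds with values here, no measured compound carries a plain hydrogen at this place, so the one step made there, an at least 10-fold lower number from compound 1 to compound 2 (1.00 log units; beyond the scatter), is the sole guide. On that basis, a move to a higher number in this assay is expected, of similar order, and the estimated change is an at least 10-fold higher number from compound 2 to compound 3 (1.00 log units; beyond the scatter). For compound 3 the expected value is 500 nM, with an estimated range of 80 nM to 4000 nM.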

Compound 3, half-maximal inhibitory concentration: > 1000 nM
Compound 3 was reported as a limit; the forecaster's own chance of this, stated with the estimate: 15%; middle value at least 2.0-fold (0.30 log units) away from the limit.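

In this assay compound 3 gives > 1000 nM, which is a limit of the assay and not a number: the limit of > 1000 nM in this assay, at which 1 of the 3 values shown sits.

With a plain hydrogen on this aromatic carbon, the step of an at least 20-fold higher number from compound 2 to compound 3 (1.30 log units; beyond the scatter) is large, so the low number of compound 2 depends on the group of 4 heavy atoms being present at this place rather than hydrogen. The other step, an at least 2.0-fold higher number from compound 1 to compound 3 (0.30 log units; that floor lies within the scatter), has a floor within the scatter, so it does not yet establish that the group of 3 heavy atoms of compound 1 improves on hydrogen.

From the compounds shown here alone, compound 2 and compound 3 both carry limits, and the true size of the gap between them stays open. Going by these compounds, whether an amine or a carboxylic acid at this place would lie nearer compound 2 or compound 3 is also open.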